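The source may hold more compounds than are shown below. What is called first, only, known or untested is meant among the compounds shown, and "the series" means these compounds.

Two members of the series have been taken through a functional assay on HEK293 cells (Homo sapiens) for cytotoxicity (a higher number here means that more compound is tolerated, a lower number that less compound is tolerated), so far. Compound 1 `COc1ccc([C@H]2CC(=O)N(c3cc(N)cc(F)c3)C2)cc1OC1CCCC1` returns only a limit in this assay, > 10000 nM, not a number. Compound 2 `COc1ccc([C@H]2CC(=O)N(c3cccc(NCCCc4ccccc4)c3)C2)cc1OC1CCCC1` likewise returns only a limit in this assay, > 10000 nM. Both readings fall on (the limit of > 10000 nM in this assay, at which 2 of the 2 values shown sit). Where compound 2 stands against compound 1 cannot be read from two limits, and no completed step between measured compounds exists in this assay.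

Compound 3 `COc1ccc([C@H]2CC(=O)N(c3cccc(NS(=O)(=O)c4c(Br)nn(C)c4Cl)c3)C2)cc1OC1CCCC1` is the next entry. It differs from compound 2 in one place: (3-bromo-5-chloro-1-methyl-1H-pyrazol-4-yl)sulfonyl in place of 3-phenylpropyl on a nitrogen on an aromatic ring. The shared core and the remainder of the molecule are kept. With both measured compounds having reached the limit, no move beyond the scatter is expected in this assay for compound 3, and the most probable outcome is that compound 3 again reports a limit rather than a number. Compound 3 is expected at 15000 nM, with a range from 5000 nM to 40000 nM. In this assay the estimated step that the limit leaves unreadable from compound 2 to compound 3 is expected to be none beyond the scatter.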

Compound 3, half-maximal cytotoxic concentration: > 10000 nM
Compound 3: a limit, no number; the forecaster's own chance of this, stated with the estimate: 75%; the middle value does not contradict the limit.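

In this assay compound 3 gives > 10000 nM, a limit and not a number. Compound 2 also reports only a limit, so no step from compound 2 to compound 3 can be read: the limit of > 10000 nM in this assay, at which 3 of the 3 values shown sit.

The compounds shown leave open whether any group on this nitrogen would return a number rather than a limit in this assay.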